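Methoxy addition on the arylidene thiosemicarbazone series

This account rests on a few compounds, and the source may have more. Where it says the series, first, only, none or still open, it means among the compounds named here.

Compound 1 `CC1=CC[C@H](C(C)(C)NC(=S)N/N=C/c2ccc(O)cc2)CC1` and compound 2 `COc1cc(/C=N/NC(=S)NC(C)(C)[C@H]2CC=C(C)CC2)ccc1O` share one core. In a functional assay on MCF7 cells (Homo sapiens) for inhibition, read by sulforhodamine B assay, with a stated time of 48 h (a higher number here means a weaker inhibitor of growth, a lower number a stronger inhibitor of growth), compound 1 gives only a limit, > 100000 nM. In this assay compound 2 gives 14800 nM, and the change methoxy in place of hydrogen on an aromatic carbon made the step of an at least 6.7-fold lower number from compound 1 to compound 2 (0.82 log units; beyond the scatter); that reading rests on (the limit of > 100000 nM in this assay, at which 1 of the 3 values shown sits). Compound 3 `CC1=CC[C@H](C(C)(C)NC(=S)N/N=C(\C)c2ccccc2)CC1` gives 20700 nM in this assay; the difference between its core and the core of compound 1 is not broken down here. Compound 4 `COc1ccc(/C(C)=N/NC(=S)NC(C)(C)[C@H]2CC=C(C)CC2)cc1` is not yet measured; it differs from compound 3 by methoxy in place of hydrogen on an aromatic carbon, the same kind of change as before, though here the place is para to a large group rather than ortho to a hydroxy group and meta to a large group. From compound 3 to compound 4 a step of a 1.7-fold lower number from compound 3 to compound 4 (0.24 log units; within the scatter) is expected in this assay, resting on the step of an at least 6.7-fold lower number from compound 1 to compound 2 (0.82 log units; beyond the scatter) tempered by the different surroundings. Compound 4 is estimated at 12000 nM, between 4000 nM and 40000 nM.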

Compound 4, concentration for 50% growth inhibition: 5000 nM
The estimate for compound 4 lay 2.4-fold (0.38 log units) above the measured number, and the stated range covers the measured number.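

In this assay, methoxy in place of hydrogen on an aromatic carbon again goes with a lower number, here a 4.1-fold lower number from compound 3 to compound 4 (0.62 log units; beyond the scatter). The direction of the change therefore carries from the core of compound 1 to the core of compound 3, and both steps lie beyond the scatter, but two cores do not show that it holds across the series: the same change on two cores in this assay, an at least 6.7-fold lower number (0.82 log units; beyond the scatter) from compound 1 to compound 2 and a 4.1-fold lower number (0.62 log units; beyond the scatter) from compound 3 to compound 4; the limit leaves it open whether they differ. On these data alone, compound 1 has a limit and not a number, so the size of the step on its core remains unknown: the limit of > 100000 nM in this assay, at which 1 of the 4 values shown sits.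

The compounds shown leave open whether an ethoxy group, an amine or a carboxylic acid in place of the methoxy would give a similar step. They also leave open whether a longer chain on the oxygen would keep it.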